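The source may report more compounds than this note shows. Statements on the series, on what has been measured and on what is new or still open speak of the compounds shown alone.

Measured so far in a functional assay on A375M cells (Homo sapiens) for cytotoxicity, read by MTT assay, with a stated time of 4 days; a higher number here means a weaker inhibitor, a lower number a stronger inhibitor:
Compound 1 `C=C1CC(CCc2ccccc2)OC1=O` gives 8700 nM
Compound 2 `C=C1C(=O)OC(c2ccccc2)C1CCCC` gives 7800 nM
Compound 3 `C=C1C(=O)OC(CCc2ccccc2)C1CCCC` gives 5000 nM

Compound 3 at 5000 nM stands within the scatter of both compound 1 and compound 2. Compound 4 `C=C1C(=O)OC(CCc2ccccc2)C1CCc1ccccc1` has phenyl in place of ethyl on a saturated chain carbon, two bonds along the chain from a saturated ring carbon and has not yet been measured. Among the measured compounds shown here, the only measured step bearing on this change is a 1.7-fold lower number from compound 1 to compound 3 (0.24 log units; within the scatter) for butyl in place of hydrogen on a saturated ring carbon, and it stays within the scatter. For the measured compounds named here, no measured compound shows this exchange directly. The expected step is a 1.3-fold lower number from compound 3 to compound 4 (0.10 log units; within the scatter) in this assay and no shift beyond the scatter is expected. Compound 4 is estimated at 4000 nM with an expected range from 1600 nM to 10000 nM for repeated measurements.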

Compound 4, half-maximal inhibitory concentration: 2700 nM
Estimate against measurement, compound 4: 1.5-fold (0.17 log units) above; the range from low to high includes it.
By their numbers in this assay, from the lowest: compounds 4, 3, 2 and 1 (each within the scatter of the next, the first and the last beyond it).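

Phenyl in place of ethyl on a saturated chain carbon, two bonds along the chain from a saturated ring carbon, gives (a 1.9-fold lower number from compound 3 to compound 4 (0.27 log units; within the scatter)) in this assay. The earlier compounds shown here carried only butyl or hydrogen at this place; the side chain now also tolerates a terminal aromatic ring, with no shift beyond the scatter. No measurement available explains this result.

Still open, as far as these compounds go, is whether an amine or a carboxylic acid on this chain, or a longer chain ending in phenyl, would move the number beyond the scatter.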